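The source may hold more compounds than are shown below. What is called first, only, known or untested is meant among the compounds shown, and "the series" means these compounds.

Working notes on the series: three esters of a shared core, compound 1 `CC(=O)Oc1ccccc1C(=O)O[C@H]1CO[C@H]2[C@@H]1OC[C@H]2OC(=O)c1cccc(O)c1`, compound 2 `CC(=O)Oc1ccccc1C(=O)O[C@H]1CO[C@H]2[C@@H]1OC[C@H]2OC(=O)c1ccc(O)cc1` and compound 3 `CC(=O)Oc1ccccc1C(=O)O[C@H]1CO[C@H]2[C@@H]1OC[C@H]2OC(=O)c1ccccc1C`, differ only in the aryl group on the carbonyl carbon. In an ADME assay on a cell-free system (plasma, Homo sapiens) for metabolic stability, with Plasma (Rattus norvegicus) as the target, read by HPLC, at pH 7.4 (a lower number here means that the compound disappears faster, a higher number that the compound lasts longer), compound 1 gives 0.0183 h, compound 2 gives 0.0198 h and compound 3 gives 0.035 h. Compound 3 sits at the largest of the three numbers, yet a 1.9-fold higher number from compound 1 to compound 3 (0.28 log units; within the scatter) and a 1.8-fold higher number from compound 2 to compound 3 (0.25 log units; within the scatter) both fall within the scatter, as does a 1.1-fold higher number from compound 1 to compound 2 (0.03 log units; within the scatter), so the three compounds are not separated in this assay.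

Compound 4 `CC(=O)Oc1ccccc1C(=O)O[C@H]1CO[C@H]2[C@@H]1OC[C@H]2OC(=O)c1ccncc1` is not yet measured. It differs from compound 3 by pyridin-4-yl in place of 2-methylphenyl on a carbonyl carbon. Within the data shown here, the steps that bear on this change are those that swap the aryl group on the same carbonyl carbon, a 1.9-fold higher number from compound 1 to compound 3 (0.28 log units; within the scatter) and a 1.8-fold higher number from compound 2 to compound 3 (0.25 log units; within the scatter), and neither leaves the scatter. Among the measured compounds shown here, no measured pair carries a ring nitrogen, so nothing shows a direction for it. The expectation is therefore no step beyond the scatter, a 1.4-fold lower number from compound 3 to compound 4 (0.15 log units; within the scatter). Compound 4 is estimated at 0.025 h, with a range of 0.012 h to 0.05 h.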

Compound 4, half-life: 0.0617 h
Estimate against measurement, compound 4: 2.5-fold (0.39 log units) below; measured number above the stated range.
By their numbers in this assay, from the lowest: compounds 1, 2, 3 and 4 (each within the scatter of the next, the first and the last beyond it).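

Pyridin-4-yl on this carbonyl carbon gives the first steps in the series that leave the scatter in this assay, with a 3.1-fold higher number from compound 2 to compound 4 (0.49 log units; beyond the scatter) and a 3.4-fold higher number from compound 1 to compound 4 (0.53 log units; beyond the scatter), both modest. Against the 2-methylphenyl ester the step stays inside the scatter, at a 1.8-fold higher number from compound 3 to compound 4 (0.25 log units; within the scatter), so compound 4 is separated from the two hydroxyphenyl esters, compound 1 and compound 2, but not from compound 3. Nothing available accounts for this separation.

With a single nitrogen-bearing ring in the set, the compounds shown leave open whether the ring nitrogen itself is what separates compound 4 from compound 1 and compound 2. Also open, from the compounds shown here alone, is how a pyrimidine ring, a saturated piperidine ring or an aryl ring carrying an amine or a carboxylic acid would read on the same carbonyl carbon.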